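Fluoro-to-methyl step on the hydrazone ring and cytotoxicity

The compounds below may be only part of what the source reports. "The series", "measured", "known", "first", "only" and "open" are said of these compounds alone.

Measured compounds:
- compound 1 `CCn1cc(C(=O)O)c(=O)c2cc(F)c(N3CCN(CN4C(=O)/C(=N\NC(=S)NO)c5cc(C)ccc54)CC3)cc21`: in an ADME assay on MT4 cells (Homo sapiens) for cytotoxicity, read by spectrophotometry, with a stated time of 5 days (on this read-out lower numbers stand for higher toxicity in this test and higher numbers for lower toxicity in this test), compound 1 gives 327000 nM
- compound 2 `CONC(=S)N/N=C1\C(=O)N(CN2CCN(c3ccccc3)CC2)c2ccc(F)cc21`: in this assay compound 2 gives 227000 nM
- compound 3 `CCn1cc(C(=O)O)c(=O)c2cc(F)c(N3CCN(CN4C(=O)/C(=N\NC(=S)NO)c5cc(F)ccc54)CC3)cc21`: in this assay compound 3 gives 208000 nM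

Compound 3 and compound 1 share one core and differ in a single change, (methyl in place of fluoro on an aromatic carbon); the resulting step is a 1.6-fold higher number from compound 3 to compound 1 (0.20 log units; within the scatter). Compound 2 carries a different core; the difference between the two cores is not broken down here. Compound 4 `CONC(=S)N/N=C1\C(=O)N(CN2CCN(c3ccccc3)CC2)c2ccc(C)cc21` has not yet been measured in this assay. It arises from compound 2 by the same change, (methyl in place of fluoro on an aromatic carbon), at a place described in the same words as for the pair above. Because the measured step of a 1.6-fold higher number from compound 3 to compound 1 (0.20 log units; within the scatter) stays inside the usual scatter, a step of comparable size is expected from compound 2 to compound 4, a 1.3-fold higher number from compound 2 to compound 4 (0.12 log units; within the scatter). Compound 4 is therefore estimated at 300000 nM, with an expected range from 150000 nM to 600000 nM.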

Compound 4, half-maximal cytotoxic concentration: 276000 nM
The estimate for compound 4 lay 1.1-fold (0.04 log units) above the measured number; low and high end bracket the measured number.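

In this assay, methyl in place of fluoro gives a 1.2-fold higher number from compound 2 to compound 4 (0.08 log units; within the scatter), a step inside the scatter. Set beside the earlier step, the two cores show no difference: the same change on two cores in this assay, a 1.6-fold higher number (0.20 log units; within the scatter) from compound 3 to compound 1 and a 1.2-fold higher number (0.08 log units; within the scatter) from compound 2 to compound 4, 1.3-fold (0.11 log units) apart, within the scatter of two such steps. Going by these compounds alone, this shows only that the change gave no step beyond the scatter on either of these two cores; it does not show that the change has any real effect on cytotoxicity, and two pairs set no rule for other cores.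

The compounds shown leave open whether another group on this aromatic carbon, such as chloro, a nitrile or an amine, would move the number beyond the scatter.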